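The source may report more compounds than this note shows. Statements on the series, on what has been measured and on what is new or still open speak of the compounds shown alone.

Measured compounds in a functional assay on HL-60 cells (Homo sapiens) for cytotoxicity, read by CCK-8 assay, with a stated time of 72 h; a higher number here means a weaker inhibitor, a lower number a stronger inhibitor:
Compound 1 `C=CCn1c(=O)/c(=C\c2cccc(F)c2)[nH]c(=O)/c1=C\c1ccccc1OC` gives 8890 nM.
Compound 2 `C=CCn1c(=O)/c(=C\c2cc(Br)ccc2F)[nH]c(=O)/c1=C\c1ccccc1OC` gives 17400 nM.
Compound 3 `C=CCn1c(=O)/c(=C\c2cccc(Br)c2)[nH]c(=O)/c1=C\c1ccccc1OC` gives 5200 nM.

Compound 1 stands second highest of these three numbers. Compound 3 lies nearest, with a 1.7-fold lower number from compound 1 to compound 3 (0.23 log units; within the scatter), and compound 2 furthest, with a 2.0-fold higher number from compound 1 to compound 2 (0.29 log units; within the scatter); neither of these steps leaves the scatter. The unmeasured compound 4 `C=CCn1c(=O)/c(=C\c2cc(F)ccc2C)[nH]c(=O)/c1=C\c1ccccc1OC` differs from compound 1 by methyl in place of hydrogen on an aromatic carbon. Within the data shown here, two measured steps bear on this change. The step of a 2.0-fold higher number from compound 1 to compound 2 (0.29 log units; within the scatter), in which 5-bromo-2-fluorophenyl replaced 3-fluorophenyl, raised the number within the scatter, and the step of a 3.3-fold lower number from compound 2 to compound 3 (0.52 log units; beyond the scatter), in which hydrogen replaced fluoro on an aromatic carbon, lowered it beyond the scatter. Taken together, among these compounds a group sitting ortho to the large group went with a higher number. Compound 4 is therefore expected to give a higher number than compound 1, with a 1.8-fold higher number from compound 1 to compound 4 (0.26 log units; within the scatter) as the expected step. The estimate for compound 4 in this assay is 16000 nM, with a range from 6500 nM to 40000 nM.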

Compound 4, half-maximal inhibitory concentration: 2600 nM
Compound 4: middle estimate off by 6.2-fold (0.79 log units), on the high side; the measured number lies below the stated range.
By their numbers in this assay, from the lowest: compounds 4, 3, 1 and 2 (each within the scatter of the next, the first and the last beyond it).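

In this assay, a methyl group ortho to a large group and para to a fluoro group went with a lower number, a 3.4-fold lower number from compound 1 to compound 4 (0.53 log units; beyond the scatter), so a group in this place does not by itself raise the number, as compound 2 had suggested. Exchanging the 5-bromo-2-fluorophenyl for 5-fluoro-2-methylphenyl gives a larger change, a 6.7-fold lower number from compound 2 to compound 4 (0.83 log units; beyond the scatter), whereas the comparison with 3-bromophenyl, a 2.0-fold lower number from compound 3 to compound 4 (0.30 log units; within the scatter), stays within the scatter, so these two groups cannot be told apart here. Nothing available explains why the methyl group goes with the lower number.

On these data alone, it remains open whether an ethyl, a methoxy or an amine in place of the methyl would also go with a lower number. As far as these compounds go, it is equally open whether the methyl would do so with bromo in place of the fluoro group.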